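Amide aryl swap: estimate for compound 3

The source may hold more compounds than are shown below. What is called first, only, known or untested is meant among the compounds shown, and "the series" means these compounds.

Compound 1 `COc1ccc(C(=O)Nc2cccc(-c3oc4cc(-c5ccc(F)cc5)ccc4c(=O)c3O)c2)cc1` and compound 2 `O=C(Nc1cccc(-c2oc3cc(-c4ccc(F)cc4)ccc3c(=O)c2O)c1)c1ccc(Cl)nc1` share one core and differ only in the aryl group on the carbonyl carbon of the amide. In a functional assay on HCC1937 cells (Homo sapiens) for antiproliferative activity, read by CCK-8 assay, with a stated time of 72 h (on this read-out lower numbers stand for stronger inhibition and higher numbers for weaker inhibition), compound 1 gives 5490 nM and compound 2 gives 7550 nM. Among the measured compounds shown here, the single measured step, a 1.4-fold higher number from compound 1 to compound 2 (0.14 log units; within the scatter), lies within the scatter. On these two numbers compound 2 stands highest, with compound 1 nearest and within the scatter of it, so neither can be called the more potent of the pair. Compound 3 `N#Cc1ccc(C(=O)Nc2cccc(-c3oc4cc(-c5ccc(F)cc5)ccc4c(=O)c3O)c2)cc1` is not yet measured and carries 4-cyanophenyl in place of 6-chloropyridin-3-yl on a carbonyl carbon. For the measured compounds named here, the only step that bears on this position, a 1.4-fold higher number from compound 1 to compound 2 (0.14 log units; within the scatter), exchanged one aryl group for another at the same carbonyl carbon and stayed within the scatter, and no other measured step touches this place. No step beyond the scatter is therefore expected in this assay for this exchange. The expected step is a 1.2-fold lower number from compound 2 to compound 3 (0.07 log units; within the scatter), essentially flat. Compound 3 is accordingly estimated at 6500 nM in this assay, with a range from 2500 nM to 16000 nM.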

Compound 3, half-maximal inhibitory concentration: 2990 nM
Compound 3: the middle estimate sits 2.2-fold (0.34 log units) above what was measured; measured number inside the range.
By their numbers in this assay, from the lowest: compounds 3, 1 and 2 (each within the scatter of the next, the first and the last beyond it).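

In this assay, among the compounds shown here, the exchange of 6-chloropyridin-3-yl for 4-cyanophenyl on the carbonyl carbon gives a 2.5-fold lower number from compound 2 to compound 3 (0.40 log units; beyond the scatter) and is the only step at this place that lies beyond the scatter, so the aryl group on the amide carbonyl can shift the read-out, though only modestly so far. The other step into compound 3, with cyano in place of methoxy on an aromatic carbon, gives a 1.8-fold lower number from compound 1 to compound 3 (0.26 log units; within the scatter) and stays within the scatter, so that change cannot be read as a real difference. Compound 3 therefore separates from compound 2 but not from compound 1, and none of the three aryl groups can be named the best at this place.

What lies behind the step between compound 2 and compound 3 stays open, as no measurement at hand bears on it. Also open is whether a carboxylic acid or an amine in place of the cyano on the aromatic carbon, or a saturated ring such as cyclohexyl in place of the whole aryl group on the carbonyl carbon, would move the number further than the modest step seen among these aryl amides.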